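Notes on a fourth analogue of the shared core

The compounds below may be only part of what the source reports. "The series", "measured", "known", "first", "only" and "open" are said of these compounds alone.

Compound 1 `NCC(=O)NCc1nnc(-c2ccccc2)o1` gives 155 nM in an assay for inhibition of histone deacetylase 8 (Homo sapiens), read by fluorescence, with a stated time of 15 min; a higher number here means a weaker inhibitor, a lower number a stronger inhibitor. Compound 2 `NCC(=O)NCc1nnc(-c2ccc(F)cc2)o1` gives 135 nM in this assay, and compound 3 `COc1ccc(-c2nnc(CNC(=O)CN)o2)cc1` gives 142 nM. The number for compound 3 is neither the highest nor the lowest of the three, yet all three sit within the scatter of one another: a 1.1-fold lower number from compound 1 to compound 3 (0.04 log units; within the scatter) and a 1.1-fold higher number from compound 2 to compound 3 (0.02 log units; within the scatter). Compound 4 `NCC(=O)NCc1nnc(-c2ccc([N+](=O)[O-])cc2)o1` differs from compound 3 by nitro in place of methoxy on an aromatic carbon. Among the measured compounds shown here, the steps that bear on this are a 1.1-fold lower number from compound 1 to compound 2 (0.06 log units; within the scatter), a 1.1-fold lower number from compound 1 to compound 3 (0.04 log units; within the scatter) and a 1.1-fold higher number from compound 2 to compound 3 (0.02 log units; within the scatter), each an exchange at the same aromatic carbon and each within the scatter. For compound 4 the expected step is therefore a 1.0-fold lower number from compound 3 to compound 4 (0.01 log units; within the scatter), with no direction beyond the scatter. Compound 4 is estimated at 140 nM, within the range 65 nM to 300 nM.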

Compound 4, half-maximal inhibitory concentration: 134 nM
Compound 4: the middle estimate sits 1.0-fold (0.02 log units) above what was measured, within the range that was stated.
By their numbers in this assay, from the lowest: compounds 4, 2, 3 and 1 (each within the scatter of the next).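

Nitro joins hydrogen, fluoro and methoxy at this aromatic carbon, para to a large group, with no step beyond the scatter in this assay: a 1.1-fold lower number from compound 3 to compound 4 (0.03 log units; within the scatter) and a 1.0-fold lower number from compound 2 to compound 4 (0.00 log units; within the scatter) and a 1.2-fold lower number from compound 1 to compound 4 (0.06 log units; within the scatter). The exchange therefore brings in a group with more heavy atoms than methoxy and a double bond outside aromatic rings, and the number stays within the scatter of all three earlier compounds. No evidence at hand bears on this result.

Going by these compounds, whether an amine, a carboxylic acid or a longer chain at this carbon would give a step beyond the scatter remains open. So does the effect of any change elsewhere on the shared core.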